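The compounds below may be only part of what the source reports. "The series", "measured", "known", "first", "only" and "open" are said of these compounds alone.

In a functional assay on MKN-45 cells (Homo sapiens) for cytotoxicity, read by MTT assay, with a stated time of 72 h (on this read-out higher numbers stand for weaker inhibition and lower numbers for stronger inhibition), compound 1 `COc1cc2c(Oc3ccc(NC(=O)/C=C/S(=O)(=O)c4ccccc4F)cc3F)ccnc2cc1OCCCN1CCN(C)CC1` gives 280 nM, compound 2 `COc1cc2c(Oc3ccc(NC(=O)/C=C/S(=O)(=O)c4ccccc4OC)cc3F)ccnc2cc1OCCCN1CCN(C)CC1` gives 430 nM, and compound 3 `COc1ccc(S(=O)(=O)/C=C/C(=O)Nc2ccc(Oc3ccnc4cc(OCCCN5CCN(C)CC5)c(OC)cc34)c(F)c2)cc1` gives 2770 nM. Compound 2 thus holds the second highest number of the three, close to compound 1 and well apart from compound 3. Compound 4 `COc1cc2c(Oc3ccc(NC(=O)/C=C/S(=O)(=O)c4ccccc4OC)cc3F)ccnc2cc1OCCCN1CCC(C)CC1` differs from compound 2 in one place: 4-methylpiperidin-1-yl in place of 4-methylpiperazin-1-yl on a saturated chain carbon, three bonds along the chain from an oxygen on an aromatic ring. Among the compounds with values here, none of the measured steps touches this saturated chain carbon; each changes the group on the sulfonyl sulfur, where a 1.5-fold higher number from compound 1 to compound 2 (0.19 log units; within the scatter) stayed within the scatter while a 6.4-fold higher number from compound 2 to compound 3 (0.81 log units; beyond the scatter) and a 9.9-fold higher number from compound 1 to compound 3 (1.00 log units; beyond the scatter) went beyond it. The change at the chain has no measured guide, so no step beyond the scatter is expected in this assay. Compound 4 is therefore estimated at 500 nM, with a range from 200 nM to 1500 nM, which would mean a 1.2-fold higher number from compound 2 to compound 4 (0.07 log units; within the scatter).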

Compound 4, half-maximal inhibitory concentration: 2030 nM
Compound 4: middle estimate off by 4.1-fold (0.61 log units), on the low side, and the stated range ends below it.
By their numbers in this assay, from the lowest: compounds 1 and 2 (each within the scatter of the next); then compounds 4 and 3 (each within the scatter of the next).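

The saturated chain carbon is not a silent position: exchanging 4-methylpiperazin-1-yl for 4-methylpiperidin-1-yl, which keeps seven heavy atoms but turns one ring nitrogen into carbon, gives a 4.7-fold higher number from compound 2 to compound 4 (0.67 log units; beyond the scatter). A change on the chain can therefore move the number beyond the scatter, as changes on the sulfonyl sulfur did earlier. No available evidence accounts for this shift.

Still open, from the compounds shown here alone, is how a morpholine or a dimethylamino group would behave at this position. Also open, going by these compounds, is whether this exchange has a similar effect with the 2-fluorophenyl group of compound 1.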